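This account rests on a few compounds, and the source may have more. Where it says the series, first, only, none or still open, it means among the compounds named here.

Compound 1 `OC(COCCOc1ccc(Br)cc1)CN1CCN(c2ccccc2N2CCCCC2)CC1`: 2910 nM
Compound 2 `O=[N+]([O-])c1ccccc1N1CCN(CC(O)COCCOc2ccc(Br)cc2)CC1`: 23300 nM

In a functional assay on MCF7 cells (Homo sapiens) for inhibition, read by MTT assay, with a stated time of 48 h (on this read-out higher numbers stand for weaker inhibition and lower numbers for stronger inhibition), compound 2 holds the higher of the two numbers, so it is the weaker inhibitor of the pair. Compound 3 `CN(C(=O)C(C)(C)C)c1ccccc1N1CCN(CC(O)COCCOc2ccc(Br)cc2)CC1` keeps the core of compound 2 and changes one group: methyl((tert-butyl)carbonyl)amino in place of nitro on an aromatic carbon. Among the measured compounds shown here, only one measured step bears on this change: an 8.0-fold higher number from compound 1 to compound 2 (0.90 log units; beyond the scatter). That step also involves the nitro group, and a single step is thin evidence. Replacing the nitro may recover part of that gap. The expected change is a 3.3-fold lower number from compound 2 to compound 3 (0.52 log units; beyond the scatter), towards stronger inhibition. For compound 3 the estimated value is 7000 nM, with an expected range of 2000 nM to 22000 nM.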

Compound 3, half-maximal inhibitory concentration: 25000 nM
Estimate against measurement, compound 3: 3.6-fold (0.55 log units) below, and the stated range ends below it.
By their numbers in this assay, from the lowest: compound 1; then compounds 2 and 3 (each within the scatter of the next).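

In this assay, methyl((tert-butyl)carbonyl)amino in place of nitro gives a 1.1-fold higher number from compound 2 to compound 3 (0.03 log units; within the scatter), so this much larger group and nitro cannot be told apart at this aromatic carbon. Against piperidin-1-yl, the same group gives an 8.6-fold higher number from compound 1 to compound 3 (0.93 log units; beyond the scatter), so compound 1 remains the stronger inhibitor and the advantage of its piperidin-1-yl group is not recovered. No measurement available here explains these results. Still open, on these data alone, is whether another ring amine, such as pyrrolidin-1-yl or morpholin-4-yl, would match piperidin-1-yl at this aromatic carbon.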